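The source may report more compounds than this note shows. Statements on the series, on what has been measured and on what is new or still open speak of the compounds shown alone.

Compound 1 `Cc1ccc2nc(NC(=O)CSc3nc4c(c(=O)n3-c3ccc(F)cc3)SCC4)sc2c1`: 3500 nM
Compound 2 `COc1ccccc1-n1c(SCC(=O)Nc2nc3ccc(C)cc3s2)nc2c(c1=O)SCC2`: 280 nM

In a functional assay on HEK293 cells (Homo sapiens) for antiproliferative activity, read by MTT assay, with a stated time of 48 h (a lower number here means that less compound is needed, a higher number that more compound is needed for the effect), compound 2 has the lower of the two numbers. Compound 3 `Cc1ccc2nc(NC(=O)CSc3nc4c(c(=O)n3Cc3ccccc3)SCC4)sc2c1` has benzyl in place of 2-methoxyphenyl on an aromatic nitrogen. Among the compounds with values here, one measured step bears on this place, a large one: a 13-fold lower number from compound 1 to compound 2 (1.10 log units; beyond the scatter). Within the data shown here, changing this group can therefore shift the number strongly, but no measured compound carries benzyl, so the direction is uncertain. Among the measured compounds shown here, with compound 2 the lower of only two values, a moderately higher number is more likely than a lower one in this assay. The expected change is a 3.6-fold higher number from compound 2 to compound 3 (0.55 log units; beyond the scatter). For compound 3 the estimated value is 1000 nM, with a range from 250 nM to 4500 nM.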

Compound 3, half-maximal effective concentration: > 10000 nM
Compound 3 ended at the assay's limit (the forecaster's own chance of this, stated with the estimate: 10%); middle value at least 10-fold (1.00 log units) from the limit.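

In this assay compound 3 gives > 10000 nM, which is a limit of the assay and not a number. Benzyl on the aromatic nitrogen gives a higher number than either earlier group, with an at least 35-fold higher number from compound 2 to compound 3 (1.55 log units; beyond the scatter) and an at least 2.8-fold higher number from compound 1 to compound 3 (0.45 log units; beyond the scatter), so a change at this position can carry the number beyond what the assay measures, not merely shift it within range. Both steps are therefore minimum sizes, and their full size cannot be read: the limit of > 10000 nM in this assay, at which 1 of the 3 values shown sits.

The compounds shown leave open how a longer chain such as phenethyl, or a small group such as methyl, would behave on this nitrogen. They also leave open whether an amine on the phenyl ring would keep the number low.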